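A few compounds are considered here, and "the series" means these few. Any claim that something is new, unique, unknown or untested is made for them only; others in the source may bear on it.

Compound 1 `O=C1C=C(NC2CCCCC2)C(=O)c2c1nc1n2[C@H]2OC[C@@H](O)[C@H]2OC1` carries a cyclohexylamino group on its shared core. In a functional assay on MGC-803 cells (Homo sapiens) for inhibition, read by sulforhodamine B assay (on this read-out lower numbers stand for stronger inhibition and higher numbers for weaker inhibition), compound 1 gives > 8000 nM, which is a limit of the assay and not a number. Compound 1 therefore stands at the limit of > 8000 nM in this assay, at which 1 of the 2 values shown sits. Compound 2 `COc1ccc(NC2=CC(=O)c3c(nc4n3[C@H]3OC[C@@H](O)[C@H]3OC4)C2=O)cc1` is the other measured compound of the set, and in this assay compound 2 gives 2150 nM. Among the measured compounds shown here, no step between measured compounds that differ in one place is available, so the two values are only what they show: compound 2 gives a number where compound 1 gives a limit.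

Compound 3 `O=C1C=C(N2CCCCC2)C(=O)c2c1nc1n2[C@H]2OC[C@@H](O)[C@H]2OC1` is not yet measured. Its change from compound 1 is piperidin-1-yl in place of cyclohexylamino on a double-bonded ring carbon. For the measured compounds named here, since compound 1 shows only a limit, there is no measured step to lean on for this swap. The step that the limit leaves unreadable from compound 1 to compound 3 is expected to be none beyond the scatter. Compound 3 is expected to give 10000 nM, within 4000 nM to 30000 nM, with a real chance that this assay again reports only a limit.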

Compound 3, half-maximal inhibitory concentration: > 8000 nM
Compound 3 gave a limit, no number; the forecaster's own chance of this, stated with the estimate: 60%; the middle value is on the limit's open side.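

In this assay compound 3 gives > 8000 nM, a limit and not a number, just as compound 1 gives only a limit, so no step can be read between compound 1 and compound 3. As far as these compounds go, whether piperidin-1-yl and cyclohexylamino differ in strength on the shared core stays open.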